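An Ester in Place of an Amide on a Shared Core

The source may hold more compounds than are shown below. What is called first, only, known or untested is meant among the compounds shown, and "the series" means these compounds.

Compound 1 `CC(=O)C1=C(C)NC(=O)NC1c1ccoc1` and compound 2 `CCNC(=O)C1=C(C)NC(=O)NC1c1ccoc1` share one core and differ only at a carbonyl carbon. In an assay on membranes from HEK293 cells for displacement of a labelled ligand from adenosine receptor A2b (Homo sapiens), read by scintillation counting, with a stated time of 30 min, tested at 1 uM (a lower number here means less inhibition, a higher number more inhibition at the concentration tested (going by the name of the read-out)), compound 1 gives 15%, and compound 2 gives 2%; the step of a number 13 percentage points lower from compound 1 to compound 2 (beyond the scatter) leaves compound 2 as the lower of the two numbers. Compound 3 `CCC(CC)OC(=O)C1=C(C)NC(=O)NC1c1ccoc1` has not yet been measured. It differs from compound 2 as follows: (pentan-3-yl)oxy in place of ethylamino on a carbonyl carbon. Going by the values given here, the only measured step, from compound 1 to compound 2, changed the same carbonyl carbon from methyl to ethylamino and was modest; no measured step bears directly on replacing ethylamino with (pentan-3-yl)oxy. Among the compounds with values here, with both measured values low and the single step modest, compound 3 is expected to show at most a modest shift, its direction uncertain. Compound 3 is expected to show a number 6 percentage points higher from compound 2 to compound 3 (within the scatter). For compound 3 a value of 8% is estimated, within -5% to 25%.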

Compound 3, a percentage reported as inhibition, at one concentration (the size of the read-out at that concentration, not a potency): 28%
The estimate for compound 3 lay 20 percentage points below the measured number; measured number outside the range, above it.
By their numbers in this assay, from the lowest: compound 2; then compound 1; then compound 3.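

In this assay, this carbonyl carbon proves able to raise the number as well as lower it: (pentan-3-yl)oxy in place of ethylamino gives a number 26 percentage points higher from compound 2 to compound 3 (beyond the scatter) and, set against methyl, gives a number 13 percentage points higher from compound 1 to compound 3 (beyond the scatter) as well. Going by these compounds alone, earlier, only a fall had been seen at this place, so compound 3 is the first to rise above compound 1, and with both of its steps beyond the scatter, it stands highest of the three. Nothing available explains this rise, and the change cannot be split between the larger group and the loss of the hydrogen-bond donor.

As far as these compounds go, whether a smaller methoxy or ethoxy group would give a similar number remains open. So does whether a ring such as cyclopentyloxy would carry it further.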